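A few compounds are considered here, and "the series" means these few. Any claim that something is new, unique, unknown or untested is made for them only; others in the source may bear on it.

In a functional assay on MCF7 cells (Homo sapiens) for cytotoxicity (on this read-out lower numbers stand for stronger inhibition and higher numbers for weaker inhibition), compound 1 (`C=C/C=C\[C@H](C)[C@H](OC(N)=O)[C@@H](C)[C@H](O)[C@@H](C)C/C(C)=C\[C@H](C)[C@@H](O)[C@@H](C)/C=C\CCc1ccc(Oc2ccccc2)cc1`) gives 10000 nM and compound 2 (`C=C/C=C\[C@H](C)[C@H](OC(N)=O)[C@@H](C)[C@H](O)[C@@H](C)C/C(C)=C\[C@H](C)[C@@H](O)[C@@H](C)/C=C\CCc1ccc(C)c(O)c1`) gives 4000 nM while compound 3 (`C=C/C=C\[C@H](C)[C@H](OC(N)=O)[C@@H](C)[C@H](O)[C@@H](C)C/C(C)=C\[C@H](C)[C@@H](O)[C@@H](C)/C=C\CCc1cccc(Cl)c1`) gives 650 nM as the lowest number of the three. Compound 4 (`C=C/C=C\[C@H](C)[C@H](OC(N)=O)[C@@H](C)[C@H](O)[C@@H](C)C/C(C)=C\[C@H](C)[C@@H](O)[C@@H](C)/C=C\CCc1ccsc1`) is still unmeasured. It carries thiophen-3-yl in place of 3-chlorophenyl on a saturated chain carbon, two bonds along the chain from a double-bonded chain carbon. Within the data shown here, the only measured step at this place, a 6.2-fold lower number from compound 2 to compound 3 (0.79 log units; beyond the scatter) involves other groups, so it is a guide to size rather than direction. With compound 3 at 650 nM as the low end so far, a smaller step towards a higher number is expected. The expected step is a 2.3-fold higher number from compound 3 to compound 4 (0.36 log units; beyond the scatter) in this estimate. The estimated value for compound 4 is 1500 nM and the expected range runs from 400 nM at the low end to 6000 nM at the high end.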

Compound 4, half-maximal inhibitory concentration: 4000 nM
Estimate against measurement, compound 4: 2.7-fold (0.43 log units) below, within the range that was stated.
By their numbers in this assay, from the lowest: compound 3; then compounds 2 and 4 (each within the scatter of the next); then compound 1.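

In this assay putting thiophen-3-yl in place of 3-chlorophenyl gives a 6.2-fold higher number from compound 3 to compound 4 (0.79 log units; beyond the scatter) and so shows that the result at this chain end depends on which ring is present. Thiophen-3-yl against 3-hydroxy-4-methylphenyl gives no change at the digits printed from compound 2 to compound 4 (within the scatter) even though the two rings differ in size and atoms, which leaves 3-chlorophenyl apart from both. No supporting measurement explains these steps. Going by these compounds, it remains open whether the chlorine or the six-membered ring matters more, a question plain phenyl could help settle. On these data alone, how an amine or a carboxylic acid on this ring would behave also remains open.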